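Swapping the aryl substituent on the shared core

The compounds below may be only part of what the source reports. "The series", "measured", "known", "first", "only" and "open" are said of these compounds alone.

Measured so far in a functional assay on MCF7 cells (Homo sapiens) for inhibition; on this read-out lower numbers stand for stronger inhibition and higher numbers for weaker inhibition:
- compound 1, `CC/C(=C(/c1ccc(/C=C/C(=O)O)cc1)c1cc2ccccc2[nH]1)c1ccccc1Cl`: 42 nM
- compound 2, `CC/C(=C(/c1ccc(/C=C/C(=O)O)cc1)c1cc2ccccc2[nH]1)c1ccccc1C#N`: 9 nM
- compound 3, `CC/C(=C(/c1ccc(/C=C/C(=O)O)cc1)c1cc2ccccc2[nH]1)c1cccc(OC(F)(F)F)c1`: 282 nM

Compound 3 gives the highest number of the three. The nearest measured neighbour is compound 1, separated by the step of a 6.7-fold higher number from compound 1 to compound 3 (0.83 log units; beyond the scatter), and the furthest is compound 2, separated by a 31-fold higher number from compound 2 to compound 3 (1.50 log units; beyond the scatter). The step of a 4.7-fold lower number from compound 1 to compound 2 (0.67 log units; beyond the scatter) shows how much a change at the same aryl group can move the read-out in this assay.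

Compound 4, `CC/C(=C(/c1ccc(/C=C/C(=O)O)cc1)c1cc2ccccc2[nH]1)c1ccc(C(F)(F)F)cc1`, differs from compound 3 by a single change: 4-(trifluoromethyl)phenyl in place of 3-(trifluoromethoxy)phenyl on a double-bonded chain carbon bound to a double-bonded chain carbon and a saturated chain carbon. Among the compounds with values here, no measured step compares two different aryl groups of this kind against each other, so the steps seen so far bear on it only indirectly: both a 6.7-fold higher number from compound 1 to compound 3 (0.83 log units; beyond the scatter) and a 31-fold higher number from compound 2 to compound 3 (1.50 log units; beyond the scatter) show that the aryl group at this position moves the number well beyond the scatter, and in both cases the 3-(trifluoromethoxy)phenyl of compound 3 sat at the weak end. Since nothing measured tells whether 4-(trifluoromethyl)phenyl recovers any of that, the expectation for compound 4 is a step of a 1.1-fold lower number from compound 3 to compound 4 (0.05 log units; within the scatter), in effect no change beyond the scatter, with wide uncertainty. Compound 4 is therefore estimated at 250 nM, within a range from 70 nM to 900 nM.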

Compound 4, half-maximal inhibitory concentration: 139 nM
The estimate for compound 4 lay 1.8-fold (0.25 log units) above the measured number; the measured number falls inside the stated range.
By their numbers in this assay, from the lowest: compound 2; then compound 1; then compound 4; then compound 3.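

In this assay, the step of a 2.0-fold lower number from compound 3 to compound 4 (0.31 log units; beyond the scatter) shows that 4-(trifluoromethyl)phenyl and 3-(trifluoromethoxy)phenyl can be told apart at this position, although this is the smallest step among the four compounds. The group of compound 4 closes only a small part of the gap to the two stronger compounds, as the large step of a 15-fold higher number from compound 2 to compound 4 (1.19 log units; beyond the scatter) and the modest step of a 3.3-fold higher number from compound 1 to compound 4 (0.52 log units; beyond the scatter) both show. Among these four compounds, the two fluorine-bearing aryl groups therefore give the higher numbers and the 2-chlorophenyl and 2-cyanophenyl groups the lower numbers, with no compound going against that split, though nothing at hand explains it.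

The compounds shown leave open whether these gaps follow the group itself or its place on the phenyl ring, since each substituent here comes with only one place. They also leave open how an amine or a methoxy group on that phenyl ring would read out on the shared core.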